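A few compounds are considered here, and "the series" means these few. Any claim that something is new, unique, unknown or untested is made for them only; others in the source may bear on it.

Of the compounds shown here, two built on a shared core have been tested in a functional assay on the whole organism (strain albino) for inhibition, with Rattus norvegicus as the target, read by paw edema, with stated times of 30 min and 4 h, at a dose of 0.28 mmol/kg by the oral route; a lower number here means less inhibition, a higher number more inhibition at the dose given (going by the name of the read-out). Compound 1, `CCn1c(SCC(=O)Nc2ccc(/C(C)=N/O)cc2)nnc1-c1ccc(OC)cc1`, gives 73% in this assay. Compound 2, `CCn1c(SCC(=O)Nc2ccc(C(C)=O)cc2)nnc1-c1ccc(OC)c(OC)c1`, gives 69% in this assay, a number that stands within the usual scatter of the result for compound 1, so the two cannot be told apart on these data. Compound 3, `CCn1c(SCC(=O)Nc2ccc(C(C)=O)cc2)nnc1-c1ccc(OC)cc1`, has not yet been measured. It differs from compound 2 in one place: hydrogen in place of methoxy on an aromatic carbon. For the measured compounds named here, no measured pair here shows what such a change does, so the size of this step can only be estimated. The expectation is a small change in this assay, with a number 1 percentage points lower from compound 2 to compound 3 (within the scatter) falling inside the usual scatter rather than beyond it. Compound 3 is therefore estimated at 68% in this assay, within an expected range from 55% to 80%.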

Compound 3, a percentage reported as inhibition, in the whole organism at one dose (the size of the read-out at that dose, not a potency): 65%
For compound 3 the middle estimate is 3 percentage points above the measured one; low and high end bracket the measured number.
By their numbers in this assay, from the lowest: compounds 3, 2 and 1 (each within the scatter of the next).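

Going from the 3,4-dimethoxyphenyl to the 4-methoxyphenyl gives the one measured step for this change: a number 4 percentage points lower from compound 2 to compound 3 (within the scatter) in this assay. On these numbers, hydrogen and methoxy on this aromatic carbon cannot be told apart at the dose given. Compound 3 also allows a comparison at a second place, where a group of 3 heavy atoms stands in place of a group of 4 heavy atoms, with a number 8 percentage points lower from compound 1 to compound 3 (within the scatter), and nothing here offers an explanation for either result.

The compounds shown leave open what a chlorine atom, an amine or a carboxylic acid on this aromatic carbon would do, and whether any change there can move the number beyond the scatter. Each number also comes from a single dose, so it gives the size of the effect at that dose and not a potency.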